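The compounds below may be only part of what the source reports. "The series", "measured", "known", "first", "only" and "open" are said of these compounds alone.

Measured compounds in an ADME assay on Vero cells (Chlorocebus sabaeus) for cytotoxicity, read by resazurin assay, with a stated time of 3 days; a lower number here means a stronger inhibitor, a higher number a weaker inhibitor:

- Compound 1, `CCN(CC)c1cc2[nH]c(C3CCCCC3)nc2cc1NC(=O)c1ccc(OC(F)(F)F)cc1`: in this assay compound 1 gives > 100 ug/mL, which is a limit and not a number.
- Compound 2, `CCCN(CCC)c1cc2[nH]c(C3CCCCC3)nc2cc1NC(=O)c1ccccc1`: in this assay compound 2 gives > 100 ug/mL, also a limit.
- Compound 3, `CN(C)c1cc2[nH]c(C3CCCCC3)nc2cc1NC(=O)c1ccc(OC(F)(F)F)cc1`: in this assay compound 3 gives > 100 ug/mL, again a limit.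

Compound 1 therefore stands at the limit of > 100 ug/mL in this assay, at which 3 of the 3 values shown sit, and the other two values shown sit at the same limit. Within the data shown here, the one step between measured compounds that differ in a single place, a step that the two limits leave unreadable from compound 1 to compound 3, is unreadable in size because both ends are limits, so it gives no measure of how this read-out responds to any change on the shared core.

Compound 4, `CCc1ccc(C(=O)Nc2cc3nc(C4CCCCC4)[nH]c3cc2N(CC)CC)cc1`, differs from compound 1 as ethyl in place of trifluoromethoxy on an aromatic carbon. Among the measured compounds shown here, no measured step touches this position, so no measured change bears on it, and the three limits leave no trend to extend. Given that compound 1 gives only > 100 ug/mL, the step of a number no higher from compound 1 to compound 4 (the limit leaves the size open) is expected to stay unresolved, with compound 4 most likely also returning a limit. The estimate for compound 4 is 100 ug/mL, with a range from 40 ug/mL to 300 ug/mL.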

Compound 4, half-maximal inhibitory concentration: > 100 ug/mL
Compound 4 was reported as a limit (the forecaster's own chance of this, stated with the estimate: 75%); the middle value lies on the limit itself.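

The step from compound 1 to compound 4 cannot be read, as both ends in this assay are limits and not numbers: the limit of > 100 ug/mL in this assay, at which 4 of the 4 values shown sit. The compounds shown leave open whether any change on the shared core shifts this read-out at all.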